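A few compounds are considered here, and "the series" means these few. Any claim that something is new, unique, unknown or untested is made for them only; others in the source may bear on it.

Measured compounds in an assay on membranes from brain with Neuronal acetylcholine receptor; alpha4/beta2 (Rattus norvegicus) as the target; on this read-out lower numbers stand for stronger inhibition and higher numbers for weaker inhibition:
compound 1, `Clc1ncc(OC[C@@H]2CCCN2)cc1-c1cccnc1`, gives 0.021 nM
compound 2, `Clc1ncc(OC[C@@H]2CCN2)cc1-c1cccnc1`, gives 0.0081 nM
compound 3, `Brc1ncc(OC[C@@H]2CCN2)cc1-c1cccnc1`, gives 0.0066 nM

Compound 2 stands second highest of the three numbers; its nearest neighbour is compound 3, a step within the scatter, and its furthest is compound 1, a step beyond the scatter. The step of a 2.6-fold lower number from compound 1 to compound 2 (0.41 log units; beyond the scatter) is the only one that clearly moves the number, and the step of a 1.2-fold lower number from compound 2 to compound 3 (0.09 log units; within the scatter) stays within the scatter.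

Compound 4, `Fc1ccc(-c2cc(OC[C@@H]3CCN3)cnc2Cl)cn1`, differs from compound 2 by fluoro in place of hydrogen on an aromatic carbon. Neither measured step concerns this change: the first exchanges the saturated ring attached to the oxygen, the second exchanges one halogen for another on the shared core. Nothing in the measured set speaks to a fluoro on the pyridyl ring, so the expectation rests on compound 2 alone, and no step beyond the scatter is expected in this assay. Compound 4 is therefore estimated at 0.008 nM, with a range from 0.003 nM to 0.025 nM, an expected step of a 1.0-fold lower number from compound 2 to compound 4 (0.01 log units; within the scatter).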

Compound 4, inhibition constant: 0.0049 nM
Beside the measured number, compound 4's estimate is 1.6-fold (0.21 log units) above it, within the range that was stated.
By their numbers in this assay, from the lowest: compounds 4, 3 and 2 (each within the scatter of the next); then compound 1.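

In this assay, the fluoro in place of hydrogen on an aromatic carbon of the six-membered aromatic ring with 1 nitrogen, next to the ring nitrogen and para to a large group, gives a 1.7-fold lower number from compound 2 to compound 4 (0.22 log units; within the scatter) and so leaves the number within the scatter. Within the data shown here, the earlier steps changed only the saturated ring attached to the oxygen and the halogen on the shared core, so this is the first sign that the ring with 1 nitrogen can carry a substituent at this place with the number staying this low. Nothing available here explains this result.

On these data alone, whether a chloro, a methoxy or an amine at the same place would also leave the number within the scatter stays open. So does whether the fluoro would give a similar step on the pyrrolidin-2-yl compound 1 or the bromo compound 3.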